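The source may report more compounds than this note shows. Statements on the series, on what has been measured and on what is new or still open speak of the compounds shown alone.

Compound 1 `CNCc1nnc(-c2ccccc2)s1` — in a functional assay on the whole organism with Mus musculus as the target (a lower number here means that less compound is needed, a higher number that more compound is needed for the effect), compound 1 gives > 200 mg/kg, which is a limit of the assay.
Compound 2 `NCc1nnc(-c2ccccc2-c2ccccc2)s1` — in this assay compound 2 gives 20 mg/kg.
Compound 3 `CNCc1nnc(-c2ccccc2-c2ccccc2)s1` — in this assay compound 3 gives 25 mg/kg.

Compound 3 stands alongside compound 2, the step between them being a 1.3-fold higher number from compound 2 to compound 3 (0.10 log units; within the scatter). For compound 1 only the limit of > 200 mg/kg in this assay, at which 1 of the 3 values shown sits, is known. Compound 4 `CCCCCCOc1ccccc1-c1nnc(CNC)s1` differs from compound 3 by hexyloxy in place of phenyl on an aromatic carbon. Within the data shown here, the one measured step at this place is an at least 8.0-fold lower number from compound 1 to compound 3 (0.90 log units; beyond the scatter), where the phenyl entered; no measured step shows hexyloxy at all. Since compound 4 gives up that phenyl, part of the step of an at least 8.0-fold lower number from compound 1 to compound 3 (0.90 log units; beyond the scatter) may be reversed, so a rise beyond the scatter is expected for compound 4, namely a 2.0-fold higher number from compound 3 to compound 4 (0.30 log units; within the scatter). Compound 4 is therefore estimated at 50 mg/kg, within a range from 15 mg/kg to 160 mg/kg.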

Compound 4, dose for half-maximal effect: 44 mg/kg
Beside the measured number, compound 4's estimate is 1.1-fold (0.06 log units) above it; measured number inside the range.
By their numbers in this assay, from the lowest: compounds 2, 3 and 4 (each within the scatter of the next, the first and the last beyond it). At a limit, above all of these: compound 1.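

At this place, on an aromatic carbon ortho to a group of 8 heavy atoms, a second aromatic ring is not required: hexyloxy, which has no ring, replaces phenyl with a 1.8-fold higher number from compound 3 to compound 4 (0.25 log units; within the scatter) in this assay. Against hydrogen at the same place, hexyloxy also holds a gain beyond the scatter, with an at least 4.5-fold lower number from compound 1 to compound 4 (0.65 log units; beyond the scatter). Compound 1 stands at a limit, so that step is only a bound: the limit of > 200 mg/kg in this assay, at which 1 of the 4 values shown sits.

From the compounds shown here alone, whether a shorter chain such as methoxy, or a carboxylic acid or an amine at the chain's end, would serve equally stays open. So does whether hexyloxy behaves the same alongside the unmethylated amine of compound 2.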